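The source may hold more compounds than are shown below. What is called first, only, known or untested is meant among the compounds shown, and "the series" means these compounds.

Two compounds of the series have numbers in an assay on isolated protein for inhibition of histone deacetylase 8 (Homo sapiens), read by fluorescence, with a stated time of 10 min; a lower number here means a stronger inhibitor, a higher number a weaker inhibitor. Compound 1 `Cc1ccc(-c2noc(CCCCCCC(=O)Nc3ccccc3N)n2)cc1` gives 8390 nM in this assay. Compound 2 `O=C(CCCCCCc1nc(-c2ccccc2)no1)C(F)(F)F` gives 760 nM in this assay, the lower of the two numbers, and the gap to compound 1 lies beyond the scatter. Compound 3 `Cc1ccc(-c2noc(CCCCCCC(=O)C(F)(F)F)n2)cc1` is not yet measured; it differs from compound 2 by methyl in place of hydrogen on an aromatic carbon. For the measured compounds named here, no measured pair shows this change on its own, so the step from compound 2 to compound 3 is expected to stay within the scatter, in either direction; the estimate is a 1.1-fold lower number from compound 2 to compound 3 (0.04 log units; within the scatter). For compound 3 the expected number in this assay is 700 nM, with a range from 300 nM to 1800 nM.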

Compound 3, half-maximal inhibitory concentration: 3190 nM
Beside the measured number, compound 3's estimate is 4.6-fold (0.66 log units) below it; the whole stated range lies below it.
By their numbers in this assay, from the lowest: compound 2; then compound 3; then compound 1.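

In this assay, phenyl to 4-methylphenyl, para to a large group, gives a 4.2-fold higher number from compound 2 to compound 3 (0.62 log units; beyond the scatter) even though only one carbon enters, so this aromatic position is not silent. With the 4-methylphenyl held constant, trifluoromethyl in place of (2-aminophenyl)amino on the carbonyl carbon gives a 2.6-fold lower number from compound 1 to compound 3 (0.42 log units; beyond the scatter) and thus keeps an advantage in this ring context. No available measurement explains either step. As far as these compounds go, whether the rise is particular to methyl remains open, as a chloro or methoxy group at the same place would show. A phenyl compound carrying (2-aminophenyl)amino would test whether the two steps add.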